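The source may report more compounds than this note shows. Statements on the series, on what has been measured and on what is new or still open speak of the compounds shown alone.

Among the measured compounds shown here, compound 3 `COc1nc2ccccc2cc1/C=C/c1noc(-c2cccnc2)n1` is one of three compounds measured in an ADME assay on HepG2 cells (Homo sapiens) for cytotoxicity, read by sulforhodamine B assay, with a stated time of 48 h; on this read-out higher numbers stand for lower toxicity in this test and lower numbers for higher toxicity in this test; compound 3 gives > 240000 nM, which is a limit of the assay and not a number. Compound 1 `COc1cccc(-c2nc(/C=C/c3cc4ccccc4nc3OC)no2)c1` gives > 220000 nM, also a limit. Compound 2 `COc1nc2ccccc2cc1/C=C/c1noc(COc2ccccc2)n1` gives > 220000 nM, again a limit. The steps a step that the two limits leave unreadable from compound 1 to compound 3 and a step that the two limits leave unreadable from compound 2 to compound 3 therefore cannot be read, since all three values sit at limits, as the limit of > 220000 nM in this assay, at which 2 of the 3 values shown sit, and the limit of > 240000 nM in this assay, at which 1 of the 3 values shown sits, show. Compound 4 `COc1nc2ccccc2cc1/C=C/c1noc(-c2ccco2)n1` has not been measured; the change is furan-2-yl in place of pyridin-3-yl on an aromatic carbon. With every measured step unreadable, no step beyond the scatter is expected. The step of a number no higher from compound 3 to compound 4 (the limit leaves the size open) is expected. Compound 4 is expected to give 240000 nM, with a range from 100000 nM to 300000 nM, most likely again as a limit.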

Compound 4, half-maximal cytotoxic concentration: > 250000 nM
Compound 4 ended at the assay's limit; the forecaster's own chance of this, stated with the estimate: 85%; middle value at least 1.0-fold (0.01 log units) from the limit.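

Compound 4 gives a limit and not a number, as do compound 1, compound 2 and compound 3, so none of its steps to those three can be read. The compounds shown leave open at what concentration, if any, each becomes toxic in this assay.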